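Aminoquinoline series: acid dissociation and a terminal side-chain swap

This account rests on a few compounds, and the source may have more. Where it says the series, first, only, none or still open, it means among the compounds named here.

Three compounds of this series have a measured acid dissociation constant; a fourth is waiting on the same assay. In a physicochemical assay for acid dissociation, compound 1 `c1ccc(CCc2ccc3c(NCCCNCc4ccco4)ccnc3c2)cc1` gives 9.47. Compound 2 `COc1ccccc1Oc1ccc2c(NCCCNCc3ccco3)ccnc2c1` differs from compound 1 only at one aromatic carbon, and in this assay compound 2 gives 9.28. Compound 3 `COc1ccc(F)cc1CNCCCNc1ccnc2cc(Oc3ccccc3OC)ccc12` shares the same aryl ether as compound 2 but carries a different group on the chain; in this assay compound 3 gives 9.28, which puts it level with compound 2 at the digits shown and leaves compound 1 as the furthest of the three values.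

Going from compound 2 to compound 1, the change is phenethyl in place of 2-methoxyphenoxy on an aromatic carbon; the step was a number 0.19 log units higher from compound 2 to compound 1 (within the scatter). The cores of compound 2 and compound 3 differ by 5-fluoro-2-methoxyphenyl in place of furan-2-yl on a saturated chain carbon bound to an amine nitrogen, and that pair gave no change at the digits printed from compound 2 to compound 3 (within the scatter).

Compound 4 `COc1ccc(F)cc1CNCCCNc1ccnc2cc(CCc3ccccc3)ccc12` has not yet been measured. Relative to compound 3 the change is phenethyl in place of 2-methoxyphenoxy on an aromatic carbon, the same change as the one made from compound 2 to compound 1, at the same place. The expected step from compound 3 to compound 4 is a number 0.17 log units higher from compound 3 to compound 4 (within the scatter), resting on the earlier a number 0.19 log units higher from compound 2 to compound 1 (within the scatter) transferred onto compound 3 at 9.28. Compound 4 is therefore estimated at 9.45, with the likely range 9.15 to 9.75, the earlier step lying within the scatter and so carrying no strong directional weight.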

Compound 4, acid dissociation constant: 9.47
Compound 4: the middle estimate sits 0.02 log units below what was measured; the range from low to high includes it.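

In this assay, phenethyl in place of 2-methoxyphenoxy on the core with the 5-fluoro-2-methoxyphenyl chain end gives a step (a number 0.19 log units higher from compound 3 to compound 4 (within the scatter)) of the same size as on the core with the furan-2-yl chain end (a number 0.19 log units higher from compound 2 to compound 1 (within the scatter)), while the chain-end swap itself reads alike on the phenethyl pair (no change at the digits printed from compound 1 to compound 4 (within the scatter)) and on the 2-methoxyphenoxy pair (no change at the digits printed from compound 2 to compound 3 (within the scatter)). This shows that, across these two cores, the change carries over with no visible dependence on the chain end; it does not show a real shift of known size, since both steps lie within the scatter, and two cores make no rule for the whole series. Nothing at hand bears on why the four values fall as they do.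

Still open, on these data alone, is whether a group of another kind on that aromatic carbon, such as an amine or a carboxylic acid, or a longer chain in place of phenethyl, would give a step beyond the scatter. Also open, as far as these compounds go, is whether the same agreement between cores would hold with a chain end other than furan-2-yl or 5-fluoro-2-methoxyphenyl, such as a simple amide.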